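Chloro-to-Hydrogen Change Carried from Compound 1 onto Compound 3

The compounds below may be only part of what the source reports. "The series", "measured", "known", "first", "only" and "open" are said of these compounds alone.

Compound 1, `CNC(=O)c1cc(C(=O)N[C@H]2CC[C@H](O)CC2)n([C@@H](C)c2cccc(Cl)c2)n1`, gives 3.7 in a physicochemical assay for lipophilicity; on this read-out lower numbers stand for lower lipophilicity and higher numbers for higher lipophilicity. Compound 2, `CNC(=O)c1cc(C(=O)N[C@H]2CC[C@H](O)CC2)n([C@@H](C)c2ccccc2)n1`, gives 2.9 in this assay. Compound 3, `CNC(=O)c1cc(C(=O)N[C@H]2[C@@H]3C[C@@H](O)C[C@@H]32)n([C@@H](C)c2cccc(Cl)c2)n1`, gives 3.4 in this assay.

Compound 2 differs from compound 1 by hydrogen in place of chloro on an aromatic carbon, a change that gave a number 0.80 log units lower from compound 1 to compound 2 (beyond the scatter). Compound 3 differs from compound 1 in its core by a group of 7 heavy atoms (6 carbon, 1 oxygen; one three-membered non-aromatic ring of carbon only, one five-membered non-aromatic ring of carbon only) in place of a group of 7 heavy atoms (6 carbon, 1 oxygen; one six-membered non-aromatic ring of carbon only), on an amide-type nitrogen, and that step was a number 0.30 log units lower from compound 1 to compound 3 (within the scatter). Compound 4, `CNC(=O)c1cc(C(=O)N[C@H]2[C@@H]3C[C@@H](O)C[C@@H]32)n([C@@H](C)c2ccccc2)n1`, has not been measured; it differs from compound 3 by hydrogen in place of chloro on an aromatic carbon, which is the same change as that from compound 1 to compound 2, with the same place in both cases. A step of a number 0.80 log units lower from compound 3 to compound 4 (beyond the scatter) is therefore expected in this assay, because a number 0.80 log units lower from compound 1 to compound 2 (beyond the scatter) was seen for the same change on the other core. Compound 4 is estimated at 2.6, with a likely range from 2.2 to 3.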

Compound 4, distribution coefficient: 3.2
Compound 4: the middle estimate sits 0.60 log units below what was measured; measured number above the stated range.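

In this assay, hydrogen in place of chloro gave a number 0.20 log units lower from compound 3 to compound 4 (within the scatter) on this core, whereas a number 0.80 log units lower from compound 1 to compound 2 (beyond the scatter) on the core of compound 1 lies beyond the scatter, so in this pair of cores the step did not carry over at the size first seen. The change of core, read with hydrogen on the aromatic ring, gave a number 0.30 log units higher from compound 2 to compound 4 (within the scatter) and so stayed within the scatter, as it did with chloro. One pair on each core cannot show how this change behaves across the series, and nothing at hand explains the difference between the two steps.

The compounds shown leave open whether a fluoro or methoxy group at that place would give steps of similar size on both cores.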